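The compounds below may be only part of what the source reports. "The series", "measured", "known", "first", "only" and "open" are said of these compounds alone.

Working notes on the cytotoxicity series. In a toxicity assay on Vero C1008 cells (Chlorocebus sabaeus) for cytotoxicity, read by neutral red uptake, with a stated time of 5 days (a higher number here means that more compound is tolerated, a lower number that less compound is tolerated), compound 1 `C[C@H](NC(=O)C(c1cccnc1)N(C(=O)c1ccco1)c1ccc(-c2ccccc2)cc1)c1ccccc1` gives only a limit, > 200000 nM. Compound 2 `O=C(NC1CCCC1)C(c1cccnc1)N(C(=O)c1ccco1)c1ccc(-c2ccccc2)cc1` likewise gives only a limit in this assay, > 200000 nM. Going by the values given here, compound 3 `O=C(NC1CCCCC1)C(c1cccnc1)N(C(=O)c1ccco1)c1ccc(-c2ccccc2)cc1` is the one member with a number, 53500 nM, so it is the only measured point this assay can be read from directly. Compound 4 `O=C(NCCCc1ccccc1)C(c1cccnc1)N(C(=O)c1ccco1)c1ccc(-c2ccccc2)cc1` is the next member: 3-phenylpropyl in place of cyclohexyl on an amide-type nitrogen. Among the compounds with values here, the measured steps that bear on it are an at least 3.7-fold lower number from compound 1 to compound 3 (0.57 log units; beyond the scatter) and an at least 3.7-fold lower number from compound 2 to compound 3 (0.57 log units; beyond the scatter), both running from a limit to the one number, consistent with the limit of > 200000 nM in this assay, at which 2 of the 3 values shown sit. Compound 1, whose amide-nitrogen group also carries a phenyl ring, sits at that limit; compound 4 is therefore expected to move back toward it, with a step of a 2.8-fold higher number from compound 3 to compound 4 (0.45 log units; beyond the scatter). For compound 4 the estimate is 150000 nM, between 50000 nM and 200000 nM.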

Compound 4, half-maximal cytotoxic concentration: > 200000 nM
Compound 4 ended at the assay's limit; the forecaster's own chance of this, stated with the estimate: 50%; middle value at least 1.3-fold (0.12 log units) away from the limit.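

In this assay, putting 3-phenylpropyl in place of cyclohexyl on the amide-type nitrogen gives an at least 3.7-fold higher number from compound 3 to compound 4 (0.57 log units; beyond the scatter). Among the groups shown, only cyclohexyl gives a measured number at this position, and the open-chain group carrying an aromatic ring joins the others at the limit: the limit of > 200000 nM in this assay, at which 3 of the 4 values shown sit. The steps among compounds 1, 2 and 4 cannot be read, since all three values are limits.

On these data alone, how compounds 1, 2 and 4 rank remains open. Also open, as far as these compounds go, is whether cycloheptyl, an amine or carboxylic acid on the chain, or a longer chain would give a number here.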